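A few compounds are considered here, and "the series" means these few. Any claim that something is new, unique, unknown or untested is made for them only; others in the source may bear on it.

In an ADME assay on J774 cells (Mus musculus) for antiproliferative activity, with a stated time of 72 h (a higher number here means that more compound is needed for the effect, a lower number that less compound is needed), compound 1 `CCc1c(C)[nH]c2cc(OCCCOC(=O)C(CC)C(C)=O)c(Cl)cc2c1=O` offers no comparison, as its entry reads "not determined" (no result reported). Within the data shown here, that leaves only two numbers. Compound 2 `CCCCc1cc2c(=O)c(-c3ccncc3)c(C)[nH]c2cc1OCCOc1ccccc1` gives 23000 nM and compound 3 `CCCCc1cc2c(=O)c(-c3cccc(Oc4ccc(F)cc4)c3)c(C)[nH]c2cc1OCCOc1ccccc1` gives 19000 nM. Among the measured compounds shown here, these two values lie within the scatter of each other, so compound 2 stands level with the only other compound that has a number.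

Compound 4 `CCCCc1cc2c(=O)c(-c3ccc(Cl)cc3C)c(C)[nH]c2cc1OCCOc1ccccc1` has not yet been measured. It keeps the rest of compound 2 and changes one group: 4-chloro-2-methylphenyl in place of pyridin-4-yl on an aromatic carbon. In words, 4-chloro-2-methylphenyl stands in place of pyridin-4-yl on an aromatic carbon. For the measured compounds named here, no measured pair shows a step of this kind, so the data give no direct guide to its size or direction.

With compound 2 at 23000 nM and compound 3 at 19000 nM as the only anchors, no step beyond the scatter is expected in this assay. The estimate means a 1.3-fold lower number from compound 2 to compound 4 (0.11 log units; within the scatter), an expected change that stays within the scatter. For compound 4 the expected value is 18000 nM, with an estimated range from 8000 nM to 40000 nM.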

Compound 4, half-maximal effective concentration: > 21000 nM
Compound 4: only a limit was reported (the forecaster's own chance of this, stated with the estimate: 25%); at least 1.1-fold (0.06 log units) between middle value and limit.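

In this assay compound 4 gives > 21000 nM, which is a limit and not a number. The step between compound 2 and compound 4 cannot be read from it. The compounds shown leave open how large that change from pyridin-4-yl to 4-chloro-2-methylphenyl is, and in which direction it runs.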